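A few compounds are considered here, and "the series" means these few. Any claim that something is new, unique, unknown or untested is made for them only; others in the source may bear on it.

Compound 1 `CN(C)CN1C(=O)C(=O)c2c(Br)cccc21`: 93700 nM
Compound 2 `O=C1C(=O)N(CN2CCCCC2)c2cccc(Br)c21`: 30200 nM
Compound 3 `CCN(CC)CN1C(=O)C(=O)c2c(Br)cccc21`: 20200 nM

These three compounds were tested in a functional assay on MDA-MB-231 cells (Homo sapiens) for cytotoxicity, read by sulforhodamine B assay, with a stated time of 48 h; on this read-out higher numbers stand for weaker inhibition of growth and lower numbers for stronger inhibition of growth. Compound 2 stands second highest of the three numbers: compound 3 sits close, with a 1.5-fold lower number from compound 2 to compound 3 (0.17 log units; within the scatter), while compound 1 lies further off, with a 3.1-fold lower number from compound 1 to compound 2 (0.49 log units; beyond the scatter). Compound 4 `O=C1C(=O)N(CN2CCCCC2)c2cccc(Cl)c21` has not been measured. It differs from compound 2 in one place: chloro in place of bromo on an aromatic carbon. Among the measured compounds shown here, none of the measured steps touches this halogen; each of them, including a 4.6-fold lower number from compound 1 to compound 3 (0.67 log units; beyond the scatter), alters only the amine on the saturated chain carbon. For the measured compounds named here, there is thus no direct precedent, and swapping one halogen for another is expected to move the read-out by no more than the scatter: a 1.0-fold lower number from compound 2 to compound 4 (0.00 log units; within the scatter). Compound 4 is therefore expected to give 30000 nM, within 12000 nM to 75000 nM.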

Compound 4, concentration for 50% growth inhibition: 26500 nM
The estimate for compound 4 lay 1.1-fold (0.05 log units) above the measured number; measured number inside the range.
By their numbers in this assay, from the lowest: compounds 3, 4 and 2 (each within the scatter of the next); then compound 1.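

Among the compounds shown here, every earlier step changed only the amine on the saturated chain carbon, so this is the first view of the aromatic carbon that carries the halogen. In this assay, chloro in place of bromo gives a 1.1-fold lower number from compound 2 to compound 4 (0.06 log units; within the scatter) and so, with the piperidin-1-yl chain kept, the two halogens cannot be told apart at this position. Nothing measured here speaks to why.

As far as these compounds go, it remains open whether a methoxy group or an amine on this aromatic carbon would shift the number. Also open, from the compounds shown here alone, is whether chloro and bromo would match with the diethylamino or dimethylamino chain.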